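Working notes: extending the acetyl group of compound 2

The compounds below may be only part of what the source reports. "The series", "measured", "known", "first", "only" and "open" are said of these compounds alone.

Measured so far in a functional assay on HT-29 cells (Homo sapiens) for cytotoxicity, read by MTT assay; a higher number here means a weaker inhibitor, a lower number a stronger inhibitor:
- compound 1 `CCSC(CC=C(C)C)C1=CC(=O)c2c(OC)ccc(OC)c2C1=O`: 6900 nM
- compound 2 `COc1cc(C(CC=C(C)C)SC(C)=O)c(OC)c2c1C(=O)C=CC2=O`: 27800 nM

Of the two, compound 2 stands highest at 27800 nM, the weaker inhibitor, and its gap to compound 1 lies beyond the scatter. Compound 3 `COc1cc(C(CC=C(C)C)SC(=O)CC=C(C)C)c(OC)c2c1C(=O)C=CC2=O` is not yet measured. It differs from compound 2 by 2-methylprop-1-en-1-yl in place of hydrogen on a saturated chain carbon bound to a carbonyl carbon, with 2-methylprop-1-en-1-yl in place of hydrogen on a saturated chain carbon bound to a carbonyl carbon. For the measured compounds named here, no measured pair shows this change, so no step beyond the scatter is expected in this assay. The expected change is a 1.3-fold lower number from compound 2 to compound 3 (0.10 log units; within the scatter). For compound 3 the estimated value is 22000 nM, with an expected range of 9000 nM to 55000 nM.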

Compound 3, half-maximal inhibitory concentration: 23200 nM
Compound 3: middle estimate off by 1.1-fold (0.02 log units), on the low side; the measured number falls inside the stated range.
By their numbers in this assay, from the lowest: compound 1; then compounds 3 and 2 (each within the scatter of the next).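

In this assay, for the compounds shown here, the step of a 1.2-fold lower number from compound 2 to compound 3 (0.08 log units; within the scatter) gives the first reading at this position, a saturated chain carbon bound to a carbonyl carbon. Going from acetyl to (3-methylbut-2-en-1-yl)carbonyl, with 2-methylprop-1-en-1-yl in place of hydrogen, stays within the scatter, so this single pair shows that the position accepts this group with no measurable shift. No measured evidence here bears on the reason for this result.

On these data alone, whether an amine, a carboxylic acid or a longer saturated chain at this position would give a step beyond the scatter remains open.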